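The source may hold more compounds than are shown below. What is called first, only, known or untested is meant among the compounds shown, and "the series" means these compounds.

Working notes on the phenylethynyl-thiazole series.

Compound 1 `Fc1cccc(C#Cc2nc3c(s2)CN(C2CCOC2)CC3)c1` carries an oxolanyl amine on the shared core and in an assay on HEK293 cells for negative allosteric modulation of metabotropic glutamate receptor 5 (Homo sapiens), read by FLIPR, with a stated time of 1 h (on this read-out lower numbers stand for stronger inhibition and higher numbers for weaker inhibition), compound 1 gives 400 nM. Compound 2 `CC1CC1C(=O)N1CCc2nc(C#Cc3ccccc3)sc2C1` replaces that amine with a (2-methylcyclopropyl)carbonyl amide. In this assay compound 2 reaches only the limit of > 10000 nM, so no number is known for it, only that it sits at the limit of > 10000 nM in this assay, at which 1 of the 2 values shown sits. The two compounds shown therefore span the range from a measured value to the ceiling of the assay.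

Compound 3 `O=C(C1CCOCC1)N1CCc2nc(C#Cc3ccccc3)sc2C1` is not yet measured. It differs from compound 2 by oxan-4-yl in place of 2-methylcyclopropyl on a carbonyl carbon. The amide carbonyl and the rest of the core are unchanged. For the measured compounds named here, with only one amide value shown, and that one a limit, there is no measured step on which to size the move from a three-membered carbon ring to a six-membered ring with one hetero atom. The step of an at least 1.1-fold lower number from compound 2 to compound 3 (0.04 log units; that floor lies within the scatter) is expected to stay within the scatter, with the result most likely again at or near the limit. Compound 3 is estimated at 9000 nM, in a range from 3000 nM to 30000 nM.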

Compound 3, half-maximal inhibitory concentration: > 10000 nM
Compound 3: only a limit was reported (the forecaster's own chance of this, stated with the estimate: 60%); middle value at least 1.1-fold (0.04 log units) away from the limit.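

In this assay, compound 2 and compound 3 both end at a limit and not at a number, so no step can be read between them: the limit of > 10000 nM in this assay, at which 2 of the 3 values shown sit.

The compounds shown leave open how far either amide lies from that limit, and whether any amide on the shared core reaches a measured number in this assay.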